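Methoxy for Methyl on the Aryl Ring of Compound 3

The source may report more compounds than this note shows. Statements on the series, on what has been measured and on what is new or still open speak of the compounds shown alone.

Three compounds sharing one core were tested in a functional assay on 143B cells (Homo sapiens) for inhibition, read by CCK-8 assay, with a stated time of 72 h, tested at 1 uM; a lower number here means less inhibition, a higher number more inhibition at the concentration tested (going by the name of the read-out). Compound 1 `COc1ccccc1N1C(=O)C(C)SC1c1cccc(C(=O)NCCCCc2ccccc2)c1` gives 61% there, and compound 2 `COc1ccccc1N1C(=O)CSC1c1cc(F)cc(C(=O)O)c1` gives 0%. Compound 3 `COc1ccc(C)cc1N1C(=O)CSC1c1cccc(C(=O)NCCCCc2ccccc2)c1` gives 29% in this assay, the second highest of the three numbers; its nearest neighbour is compound 2, lying beyond the scatter lower, and the furthest is compound 1, lying beyond the scatter higher. Compound 4 `COc1ccc(OC)c(N2C(=O)CSC2c2cccc(C(=O)NCCCCc3ccccc3)c2)c1` has not yet been measured. It differs from compound 3 in one place: methoxy in place of methyl on an aromatic carbon. Among the compounds with values here, no measured pair differs in this way, so the size of the step is open; a small move in either direction, or none beyond the scatter, is expected in this assay. The expected step is a number 1 percentage points higher from compound 3 to compound 4 (within the scatter). Compound 4 is estimated to give about 30% in this assay, within 10% to 55%.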

Compound 4, a percentage reported as inhibition, at one concentration (the size of the read-out at that concentration, not a potency): 2%
The estimate for compound 4 lay 28 percentage points above the measured number; the measured number lies below the stated range.
By their numbers in this assay, from the lowest: compounds 2 and 4 (each within the scatter of the next); then compound 3; then compound 1.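

In this assay, the change from 2-methoxy-5-methylphenyl to 2,5-dimethoxyphenyl gives a number 27 percentage points lower from compound 3 to compound 4 (beyond the scatter). Within the data shown here, this is the first reading at this aromatic carbon, meta to a large group and para to a methoxy group, and it shows that the number responds to this single exchange of methyl for methoxy. Nothing at hand explains the drop. As far as these compounds go, whether a hydroxyl, an ethyl or a chlorine on this carbon would follow the methyl or the methoxy remains open, as does the effect of leaving this carbon with only hydrogen.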